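A few compounds are considered here, and "the series" means these few. Any claim that something is new, unique, unknown or untested is made for them only; others in the source may bear on it.

In a functional assay on RAW264.7 cells (Mus musculus) for inhibition, read by ELISA, with a stated time of 24 h (a higher number here means that more compound is needed for the effect, a lower number that less compound is needed), compound 2 `CC/C=C\C[C@H]1C(=O)C=C[C@H]1CC(=O)OCCO` gives 24000 nM, compound 1 `CC/C=C\C[C@H]1C(=O)C=C[C@H]1CC(=O)OCCC` gives 23000 nM and compound 3 `CC/C=C\C[C@H]1C(=O)C=C[C@H]1CC(=O)OCCOCCOCCOC` gives 35000 nM. Compound 2 thus stands level with both others, as the measured steps stay within the scatter: a 1.0-fold higher number from compound 1 to compound 2 (0.02 log units; within the scatter), a 1.5-fold higher number from compound 2 to compound 3 (0.16 log units; within the scatter) and a 1.5-fold higher number from compound 1 to compound 3 (0.18 log units; within the scatter). Compound 4 `CC/C=C\C[C@H]1C(=O)C=C[C@H]1CC(=O)OC1CCCCC1` differs from compound 2 by cyclohexyl in place of 2-hydroxyethyl on an oxygen next to a carbonyl group, with cyclohexyl in place of 2-hydroxyethyl on an oxygen next to a carbonyl group. Going by the values given here, these steps all altered the chain, and no measured compound carries a ring at that place, so the cyclohexyl group remains untested. No shift beyond the scatter is therefore expected, and the estimated change is a 1.2-fold lower number from compound 2 to compound 4 (0.08 log units; within the scatter). The estimated value for compound 4 is 20000 nM, within an expected range from 8000 nM to 45000 nM.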

Compound 4, half-maximal effective concentration: 22000 nM
Compound 4: middle estimate off by 1.1-fold (0.04 log units), on the low side; the measured number falls inside the stated range.
By their numbers in this assay, from the lowest: compounds 4, 1, 2 and 3 (each within the scatter of the next).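

Among the compounds shown, only compound 4 carries a ring on the oxygen next to a carbonyl group, and in this assay cyclohexyl in place of 2-hydroxyethyl gives a step within the scatter (a 1.1-fold lower number from compound 2 to compound 4 (0.04 log units; within the scatter)). Cyclohexyl in place of propyl also stays within it (a 1.0-fold lower number from compound 1 to compound 4 (0.02 log units; within the scatter)), so at this place neither the ring nor the absence of a hydrogen-bond donor shifts the number beyond the scatter. No measurement shown explains this result. Open, from the compounds shown here alone, is whether an amine, a carboxylic acid or a phenyl ring at this place would move the number beyond the scatter.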